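Swapping Methyl for Nitro on an Aryl Imine

This account rests on a few compounds, and the source may have more. Where it says the series, first, only, none or still open, it means among the compounds named here.

Measured compounds:
- Compound 1, `COc1ccc(/C=C2/CN(C)/C(=N/c3ccc(C)cc3)S2)cc1`: 7600 nM
- Compound 2, `COc1ccc(/C=C2\S/C(=N\c3ccc(Cl)cc3)N(C)C2=O)cc1`: 39300 nM
- Compound 3, `FC(F)(F)c1cc(/N=C2/NC/C(=C/c3ccccc3)S2)cc(C(F)(F)F)c1`: 13500 nM

All three were tested in a functional assay on MCF7 cells (Homo sapiens) for antiproliferative activity, read by MTT assay, with a stated time of 72 h; a lower number here means a stronger inhibitor, a higher number a weaker inhibitor. Compound 1 has the lowest of the three numbers, but its gap to compound 3 is within the usual scatter of repeated runs, so those two cannot be told apart. The gap from compound 1 to compound 2 is beyond the scatter, so compound 2 is the weaker of that pair.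

The next compound, compound 4, `COc1ccc(/C=C2/CN(C)/C(=N/c3ccc([N+](=O)[O-])cc3)S2)cc1`, keeps the whole core of compound 1 and changes only one group on the aromatic ring of carbon only, at the place para to a large group:

nitro in place of methyl on an aromatic carbon

Among the measured compounds shown here, no measured pair shows what this kind of change does here, so there is nothing to lean on. For the step from compound 1 to compound 4 in this assay a small step is expected, likely within the scatter, estimated at a 1.3-fold lower number from compound 1 to compound 4 (0.10 log units; within the scatter). Compound 4 is therefore expected to give about 6000 nM, with a range from 2000 nM to 20000 nM.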

Compound 4, half-maximal inhibitory concentration: 9800 nM
Estimate against measurement, compound 4: 1.6-fold (0.21 log units) below, and the stated range covers the measured number.
By their numbers in this assay, from the lowest: compounds 1, 4 and 3 (each within the scatter of the next); then compound 2.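

In this assay the swap of nitro for methyl gives a 1.3-fold higher number from compound 1 to compound 4 (0.11 log units; within the scatter) and so the two compounds cannot be told apart. This is the first pair shown that differs in only one place, and it shows that the aromatic ring of carbon only accepts nitro in place of methyl, para to a large group, with a step that stays within the scatter. No measurement shown here accounts for why these two groups read alike.

Going by these compounds, whether an amine, a carboxylic acid or a longer chain at this same place would also stay within the scatter remains open. Compound 2 and compound 3 differ from compound 1 in more than one place, so they cannot settle that question for this position.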